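Methyl added to the unsaturated chain: measured once, expected again

The source may report more compounds than this note shows. Statements on the series, on what has been measured and on what is new or still open speak of the compounds shown alone.

Compound 1 `C/C=C/C(=O)Nc1cc2c(N3CCc4ccccc43)ncnc2cc1OC` and compound 2 `CC/C=C/C(=O)Nc1cc2c(N3CCc4ccccc43)ncnc2cc1OC` share one core and differ only in the chain attached to the amide. In a functional assay on A549 cells (Homo sapiens) for antiproliferative activity, read by MTT assay, with a stated time of 72 h (a higher number here means a weaker inhibitor, a lower number a stronger inhibitor), compound 1 gives 8290 nM and compound 2 gives 2470 nM. The change between them is methyl in place of hydrogen on a saturated chain carbon bound to a double-bonded chain carbon, and it produced a 3.4-fold lower number from compound 1 to compound 2 (0.53 log units; beyond the scatter).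

Compound 3 `CC/C=C/C(=O)Nc1cc2c(N3CCc4ccccc43)ncnc2cc1O[C@@H]1CCOC1` stands on a different core; the difference between the two cores is not broken down here. Its step from compound 2 reads a 4.4-fold higher number from compound 2 to compound 3 (0.64 log units; beyond the scatter), and in this assay compound 3 gives 10900 nM, the highest of the three numbers recorded, though against compound 1 it sits within the scatter.

Compound 4 `CC(C)/C=C/C(=O)Nc1cc2c(N3CCc4ccccc43)ncnc2cc1O[C@@H]1CCOC1` has not been measured. It differs from compound 3 by methyl in place of hydrogen on a saturated chain carbon bound to a double-bonded chain carbon and a saturated chain carbon. For the measured compounds named here, this is the same kind of change as the one from compound 1 to compound 2, not the same: in compound 1 the place is on a saturated chain carbon bound to a double-bonded chain carbon, while in compound 3 the carbon that takes the methyl is also bound to a saturated chain carbon. The expectation rests on the step of a 3.4-fold lower number from compound 1 to compound 2 (0.53 log units; beyond the scatter), and the account discounts it somewhat for the changed surroundings. Compound 4 is expected to give about 5000 nM in this assay, with a plausible range from 2000 nM to 13000 nM. That estimate amounts to an expected step of a 2.2-fold lower number from compound 3 to compound 4 (0.34 log units; beyond the scatter).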

Compound 4, half-maximal inhibitory concentration: 8520 nM
Estimate against measurement, compound 4: 1.7-fold (0.23 log units) below, within the range that was stated.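

In this assay, methyl in place of hydrogen on the core of compound 3 gives a 1.3-fold lower number from compound 3 to compound 4 (0.11 log units; within the scatter), so this change does not separate the two compounds in this read-out. Set beside the earlier step on the core of compound 1, the new step does not differ from it by more than two such steps would be expected to: the same change on two cores in this assay, a 3.4-fold lower number (0.53 log units; beyond the scatter) from compound 1 to compound 2 and a 1.3-fold lower number (0.11 log units; within the scatter) from compound 3 to compound 4, 2.6-fold (0.42 log units) apart, within the scatter of two such steps. This means that the result on the core of compound 3 does not contradict the earlier step, but it does not establish that the change carries from one core to another, as only the earlier step lies beyond the scatter, the carbon taking the methyl has different surroundings in the two pairs, and a single pair on each core cannot separate the effect of the core from that of those surroundings.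

The compounds shown leave open how the isopropyl end would read on the core of compound 1, which would test the same chain on both cores directly. They also leave open whether a longer chain, a cyclopropyl group or an amine at the end of the unsaturated chain would give a step beyond the scatter on either core.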